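This account rests on a few compounds, and the source may have more. Where it says the series, first, only, none or still open, it means among the compounds named here.

Measured so far in a functional assay on MCF7 cells (Homo sapiens) for cytotoxicity, read by MTT assay, with a stated time of 72 h; a lower number here means a stronger inhibitor, a higher number a weaker inhibitor 
compound 1 `CCC(C)=C1C(=O)N(c2ccc(Cl)cc2)N(c2ccc(Cl)cc2)C1=O` 41600 nM 
compound 2 `COc1cc(C=C2C(=O)N(c3ccc(Cl)cc3)N(c3ccc(Cl)cc3)C2=O)ccc1O` 22800 nM 
compound 3 `CC(=C1C(=O)N(c2ccc(Cl)cc2)N(c2ccc(Cl)cc2)C1=O)c1ccc(O)cc1` 76500 nM 

Compound 2 at 22800 nM sits within the scatter of compound 1 and beyond the scatter of compound 3, which has the higher number. The change 2,4-dichlorophenyl in place of 4-hydroxy-3-methoxyphenyl on a double-bonded chain carbon bound to a double-bonded ring carbon leads from compound 2 to compound 4 `O=C1C(=Cc2ccc(Cl)cc2Cl)C(=O)N(c2ccc(Cl)cc2)N1c1ccc(Cl)cc1` and puts 2,4-dichlorophenyl in place of 4-hydroxy-3-methoxyphenyl. For the measured compounds named here, no measured pair tests this exchange directly. Going by the values given here, the only measured step of a 1.8-fold higher number from compound 1 to compound 3 (0.26 log units; within the scatter) involves other groups and stays within the scatter, so it offers little ground for expecting a large move. In this assay, going by these compounds, no step beyond the scatter is therefore expected, and the direction remains open. The expected step is a 1.1-fold higher number from compound 2 to compound 4 (0.04 log units; within the scatter) and remains an estimate. Compound 4 is expected at 25000 nM within a range of 9000 nM to 70000 nM as an estimate.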

Compound 4, half-maximal inhibitory concentration: > 128000 nM
Compound 4 ended at the assay's limit; the forecaster's own chance of this, stated with the estimate: 10%; middle value at least 5.1-fold (0.70 log units) away from the limit.
By their numbers in this assay, from the lowest: compounds 2, 1 and 3 (each within the scatter of the next, the first and the last beyond it). At a limit, above all of these: compound 4.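

At the double-bonded chain carbon bound to a double-bonded ring carbon, 2,4-dichlorophenyl in place of 4-hydroxy-3-methoxyphenyl gives an at least 5.6-fold higher number from compound 2 to compound 4 (0.74 log units; beyond the scatter) in this assay, the first single change shown that moves beyond the scatter, unlike a 1.8-fold higher number from compound 1 to compound 3 (0.26 log units; within the scatter). Compound 4 stands at a limit of the assay, not at a number: the limit of > 128000 nM in this assay, at which 1 of the 4 values shown sits. Going by these compounds, the real size of this step therefore stays unknown.

The exchange replaces hydroxy, methoxy and chlorine together, so the compounds shown do not assign the step to any one of them. On these data alone, what an amine on this ring would do also stays open.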